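Stripping the Side Chain from Compound 3

The source may hold more compounds than are shown below. What is called first, only, known or untested is meant among the compounds shown, and "the series" means these compounds.

For the measured compounds named here, the series shares an aryl-substituted isoindolinone core, and in an assay on cells for inhibition of cytochrome P450 11B2, mitochondrial (Homo sapiens), read by HTRF (on this read-out higher numbers stand for weaker inhibition and lower numbers for stronger inhibition), the three measured members spread over a wide span. Compound 1 `C[C@@H](NS(C)(=O)=O)c1cncc(N2C(=O)c3ccc(Cl)cc3C2(C)C)c1` gives 8 nM, compound 2 `CC(=O)N[C@@H]1CCCc2c1cncc2N1C(=O)c2ccc(Cl)cc2[C@H]1C` gives 130 nM, and compound 3 `CCS(=O)(=O)NCc1cncc(N2C(=O)c3ccc(Cl)cc3C2(C)C)c1` gives 92 nM. Compound 3 thus holds the second highest of the three numbers, with compound 2 close to it within the scatter and compound 1 far below it. Going by the values given here, the only single-point step among the measured compounds is a 12-fold higher number from compound 1 to compound 3 (1.06 log units; beyond the scatter), where one sulfonamide-bearing chain was swapped for another on the same aromatic carbon; the side chain therefore clearly matters on this read-out.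

Compound 4 `CC1(C)c2cc(Cl)ccc2C(=O)N1c1cccnc1` takes a further step in that direction by deleting the chain altogether: hydrogen in place of ((ethylsulfonyl)amino)methyl on an aromatic carbon. Among the compounds with values here, no measured step removes a whole side chain, so the expectation must be drawn from the sensitivity that compound 1 and compound 3 showed when their chains were exchanged. Compound 4 is accordingly expected to lose potency, with a step of a 22-fold higher number from compound 3 to compound 4 (1.34 log units; beyond the scatter) in the direction of higher numbers. The estimate for compound 4 in this assay is 2000 nM, within a range of 400 nM to 10000 nM.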

Compound 4, half-maximal inhibitory concentration: 108 nM
The estimate for compound 4 lay 19-fold (1.27 log units) above the measured number, outside the stated range (below it).
By their numbers in this assay, from the lowest: compound 1; then compounds 3, 4 and 2 (each within the scatter of the next).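

In this assay, putting hydrogen in place of ((ethylsulfonyl)amino)methyl on this aromatic carbon gives a 1.2-fold higher number from compound 3 to compound 4 (0.07 log units; within the scatter) and so leaves the number within the scatter: the whole chain of compound 3 can be deleted with no readable change, which the exchange of one chain for another could not show. For the compounds shown here, the large gap seen earlier is therefore not a general feature of having a chain at this position, since the hydrogen-bearing compound still stands apart from the chain of compound 1, with a 14-fold higher number from compound 1 to compound 4 (1.13 log units; beyond the scatter) as the step, and on these numbers only that chain, not the one in compound 3, separates itself from hydrogen. Nothing available here explains why the two chains, alike in their atom counts, behave so differently.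

The compounds shown leave open which of the differences between the chains of compound 1 and compound 3 carries the gap, as no chain here differs from either in only one feature. They also leave open whether an amine, a carboxylic acid or a longer chain on this aromatic carbon would stay level with hydrogen or move away from it.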